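The source may report more compounds than this note shows. Statements on the series, on what has been measured and on what is new or still open speak of the compounds shown alone.

Compound 1 `C=C(C)[C@@H]1CC=C(Cn2cc(COc3ccc(C4NC(=O)NC(C)=C4C(=O)OCC)cc3)nn2)CC1` gives 77100 nM in a functional assay on HT-29 cells (Homo sapiens) for inhibition, read by sulforhodamine B assay, with a stated time of 48 h; a higher number here means a weaker inhibitor of growth, a lower number a stronger inhibitor of growth. Compound 2 `C=C(C)[C@@H]1CC=C(Cn2cc(COc3ccc(C4NC(=O)NC(C)=C4C(=O)OCC)cc3OC)nn2)CC1` differs from compound 1 by a single change: methoxy in place of hydrogen on an aromatic carbon. Compound 2 in this assay reaches only a limit of the assay, > 100000 nM. The step of an at least 1.2-fold higher number from compound 1 to compound 2 (0.11 log units; that floor lies within the scatter) is therefore bounded by the limit of > 100000 nM in this assay, at which 1 of the 3 values shown sits. Compound 3 `C=C(C)[C@@H]1CC=C(Cn2cc(COc3cccc(C4NC(=O)NC(C)=C4C(C)=O)c3)nn2)CC1` has a different core; the difference between the two cores is not broken down here. In this assay compound 3 gives 86200 nM. Compound 4 `C=C(C)[C@@H]1CC=C(Cn2cc(COc3cc(C4NC(=O)NC(C)=C4C(C)=O)ccc3OC)nn2)CC1` is not yet measured; it differs from compound 3 by the same kind of change, (methoxy in place of hydrogen on an aromatic carbon), the surroundings differing in that the new group sits para to a large group rather than meta to a large group. Since the step from compound 1 to compound 2 was an at least 1.2-fold higher number from compound 1 to compound 2 (0.11 log units; that floor lies within the scatter), the expected step of a 1.4-fold higher number from compound 3 to compound 4 (0.14 log units; within the scatter) is estimated to be similar, again toward the limit. Compound 4 is estimated at 120000 nM.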

Compound 4, concentration for total growth inhibition: 96000 nM
For compound 4 the middle estimate is 1.3-fold (0.10 log units) above the measured one, within the range that was stated.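

Within this assay methoxy in place of hydrogen on an aromatic carbon gives a 1.1-fold higher number from compound 3 to compound 4 (0.05 log units; within the scatter) and so no readable change on this core. Set beside the same change on the core of compound 1, nothing separates the two steps, yet nothing proves them equal either: the same change on two cores in this assay, an at least 1.2-fold higher number (0.11 log units; that floor lies within the scatter) from compound 1 to compound 2 and a 1.1-fold higher number (0.05 log units; within the scatter) from compound 3 to compound 4; the limit leaves it open whether they differ. Going by these compounds, one of the two steps rests on a limit, so its true size stays unknown: the limit of > 100000 nM in this assay, at which 1 of the 4 values shown sits.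

On these data alone, whether a hydroxyl, a fluorine or a longer chain such as ethoxy in that same place would give a step beyond the scatter stays open. So does whether the methoxy step would stay this small on further cores.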